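Thiazolylidene hydrazides on C6 cells: chloro to methoxy

A few compounds are considered here, and "the series" means these few. Any claim that something is new, unique, unknown or untested is made for them only; others in the source may bear on it.

Measured so far:
compound 1, `O=C(CSc1nnnn1-c1ccccc1)N/N=c1/scc(-c2ccc(Cl)cc2)n1-c1ccccc1`, 62.3%
compound 2, `COc1ccc(-c2cs/c(=N/NC(=O)CSc3nnc(C)s3)n2-c2ccccc2)cc1`, 42.6%
compound 3, `O=C(CSc1ncccn1)N/N=c1/scc(-c2ccc(Cl)cc2)n1-c1ccccc1`, 91.1%

In a functional assay on C6 cells (Rattus norvegicus) for cytotoxicity, read by MTT assay, with a stated time of 24 h, tested at 25 ug/mL (on this read-out higher numbers stand for a weaker effect at the one concentration tested and lower numbers for a stronger effect), compound 3 stands highest of the three numbers shown; compound 1 comes nearest, and compound 2 lies furthest. Among the measured compounds shown here, the only measured step with one change is a number 28.8 percentage points higher from compound 1 to compound 3 (beyond the scatter), and it concerns the group on the sulfur, not the aromatic ring that is altered here.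

Compound 4 is `COc1ccc(-c2cs/c(=N/NC(=O)CSc3ncccn3)n2-c2ccccc2)cc1`, not yet measured. It differs from compound 3 by methoxy in place of chloro on an aromatic carbon. For the measured compounds named here, no measured step in this assay bears directly on this change. Compound 2 carries the methoxy group and compound 3 carries the chloro group, but they also differ on the sulfur, so the two values can only be set side by side: compound 2 gives 42.6% against the higher number of compound 3. Taken together with compound 1 and compound 3, this leaves the effect of the methoxy group itself undetermined, and the expectation rests on wide margins.

The step to compound 4 in this assay is estimated as a number 16.1 percentage points lower from compound 3 to compound 4 (beyond the scatter), a modest decrease with a range that reaches the scatter. Compound 4 is expected to give about 75%, between 50% and 95%.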

Compound 4, a percentage reported as activity, at one concentration (the size of the read-out at that concentration, not a potency): 74%
The estimate for compound 4 lay 1 percentage points above the measured number, and the stated range covers the measured number.
By their numbers in this assay, from the lowest: compound 2; then compound 1; then compound 4; then compound 3.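

In this assay the change from 4-chlorophenyl to 4-methoxyphenyl can now be read directly with pyrimidin-2-yl held fixed on the sulfur: a number 17.1 percentage points lower from compound 3 to compound 4 (beyond the scatter), so at the one concentration tested methoxy goes with the stronger effect in this pair. With methoxy held fixed, a number 31.4 percentage points higher from compound 2 to compound 4 (beyond the scatter), which shows that the group on the sulfur also moves the number in the methoxy compounds; together with a number 28.8 percentage points higher from compound 1 to compound 3 (beyond the scatter) in the chloro compounds, pyrimidin-2-yl carries the higher number in both pairs, though against a different partner in each. No supporting data bear on the origin of either step.

From the compounds shown here alone, the chloro to methoxy step rests on this one pair, so it remains open whether it holds with 5-methyl-1,3,4-thiadiazol-2-yl or 1-phenyl-1H-tetrazol-5-yl on the sulfur. Also open, going by these compounds, is how an amine, a carboxylic acid or a longer alkoxy chain would read in the place of methoxy, and whether the number follows any order across such groups.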